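The source may hold more compounds than are shown below. What is called first, only, known or untested is meant among the compounds shown, and "the series" means these compounds.

Measured so far:
compound 1 `CC(C)(C)c1ccc(NC(=O)N2CCCN(C(=O)CC3CCCC3)CC2)cc1`: 0.05 h
compound 2 `CC(C)CCC(=O)N1CCCN(C(=O)Nc2ccc(C(C)(C)C)cc2)CC1`: 0.05 h
compound 3 `CC(C)(C)c1ccc(NC(=O)N2CCCN(C(=O)c3ccc(C(F)(F)F)cc3)CC2)cc1`: 0.0667 h

In an in vitro ADME assay on microsomes from liver (Homo sapiens) for metabolic stability, read by LC-MS (a lower number here means that the compound disappears faster, a higher number that the compound lasts longer), compound 3 carries the nominally top number of the three, but the gaps a 1.3-fold higher number from compound 1 to compound 3 (0.13 log units; within the scatter) and a 1.3-fold higher number from compound 2 to compound 3 (0.13 log units; within the scatter) are both within the scatter, so the three compounds are not separable on these data. Compound 4 `CN(C)c1ccc(C(=O)N2CCCN(C(=O)Nc3ccc(C(C)(C)C)cc3)CC2)cc1` is unmeasured; the change is dimethylamino in place of trifluoromethyl on an aromatic carbon. Among the compounds with values here, no measured step touches a substituent on this aromatic ring. The steps that exchange the whole acyl group, a 1.3-fold higher number from compound 1 to compound 3 (0.13 log units; within the scatter) and a 1.3-fold higher number from compound 2 to compound 3 (0.13 log units; within the scatter), and the step of no change at the digits printed from compound 1 to compound 2 (within the scatter), all stay within the scatter, so nothing here supports a step beyond it. The expected step is a 1.1-fold lower number from compound 3 to compound 4 (0.05 log units; within the scatter). Compound 4 is estimated at 0.06 h, range 0.025 h to 0.15 h.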

Compound 4, half-life: 0.0667 h
The estimate for compound 4 lay 1.1-fold (0.05 log units) below the measured number; low and high end bracket the measured number.
By their numbers in this assay, from the lowest: compounds 1, 2, 3 and 4 (each within the scatter of the next).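

In this assay, within the data shown here, dimethylamino in place of trifluoromethyl on an aromatic carbon, para to a large group, gives no change at the digits printed from compound 3 to compound 4 (within the scatter), the only reading so far of a substituent change at this ring position, and it does not separate the two groups. The whole-group exchanges to 4-(dimethylamino)phenyl give a 1.3-fold higher number from compound 2 to compound 4 (0.13 log units; within the scatter) and a 1.3-fold higher number from compound 1 to compound 4 (0.13 log units; within the scatter), so the four compounds remain inseparable. Nothing available bears on why this change leaves the number within the scatter. On these data alone, whether a carboxylic acid or a morpholine at this ring carbon would give a step beyond the scatter remains open.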